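The compounds below may be only part of what the source reports. "The series", "measured", "known", "first", "only" and "open" are said of these compounds alone.

In a functional assay on MCF7 cells (Homo sapiens) for cytotoxicity, read by MTT assay, with a stated time of 24 h (on this read-out higher numbers stand for weaker inhibition of growth and lower numbers for stronger inhibition of growth), compound 1 `N#CC1=C(N)OC(c2c[nH]c3ccccc23)=C(C#N)C1c1ccccc1F` gives 22800 nM, compound 2 `N#CC1=C(N)OC(c2c[nH]c3ccccc23)=C(C#N)C1c1ccc(Br)cc1` gives 21800 nM, and compound 3 `N#CC1=C(N)OC(c2c[nH]c3ccccc23)=C(C#N)C1c1ccc2ccccc2c1` gives 15500 nM. Compound 2 therefore stands within the scatter of both other compounds. Compound 4 `COc1ccc(C2C(C#N)=C(N)OC(c3c[nH]c4ccccc34)=C2C#N)cc1OC` keeps the shared core and carries 3,4-dimethoxyphenyl in place of 4-bromophenyl on a saturated ring carbon. Three measured steps swap the group at this same place: a 1.0-fold lower number from compound 1 to compound 2 (0.02 log units; within the scatter), a 1.5-fold lower number from compound 1 to compound 3 (0.17 log units; within the scatter), and a 1.4-fold lower number from compound 2 to compound 3 (0.15 log units; within the scatter). All three lie within the scatter. Within the data shown here, no measured compound carries 3,4-dimethoxyphenyl, so this remains an extrapolation, and no step beyond the scatter is expected in this assay. For compound 4 the estimated value is 20000 nM, with an expected range of 9000 nM to 40000 nM. The expected step is a 1.1-fold lower number from compound 2 to compound 4 (0.04 log units; within the scatter).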

Compound 4, concentration for 50% growth inhibition: 20600 nM
Compound 4: the middle estimate sits 1.0-fold (0.01 log units) below what was measured; measured number inside the range.
By their numbers in this assay, from the lowest: compounds 3, 4, 2 and 1 (each within the scatter of the next).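

In this assay the 3,4-dimethoxyphenyl group on the saturated ring carbon stays within the scatter of all three earlier groups, with a 1.1-fold lower number from compound 2 to compound 4 (0.02 log units; within the scatter) and a 1.1-fold lower number from compound 1 to compound 4 (0.04 log units; within the scatter) and a 1.3-fold higher number from compound 3 to compound 4 (0.12 log units; within the scatter). The position thus tolerates a group with 2 hydrogen-bond acceptors in place of 4-bromophenyl, which has 0, without a step beyond the scatter. Nothing available explains this absence of a step.

On these data alone, all four groups here are aromatic, so the effect of an aliphatic amine, a carboxylic acid or a longer alkyl chain at this position remains open. So does any change to the 1H-indol-3-yl group.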